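The source may hold more compounds than are shown below. What is called first, only, known or untested is meant among the compounds shown, and "the series" means these compounds.

In a functional assay on HCT-15 cells (Homo sapiens) for antiproliferative activity (on this read-out higher numbers stand for weaker inhibition of growth and lower numbers for stronger inhibition of growth), compound 1 (`c1ccc(-c2cc(-c3cccnc3)nc(-c3ccccn3)c2)cc1`) gives 40.9 ug/mL and compound 2 (`c1ccc(-c2cc(-c3ccsc3)cc(-c3ccccn3)n2)nc1`) gives 0.29 ug/mL as the lower of the two numbers, a gap well beyond the scatter of repeat measurements. Compound 3 (`c1ccc(-c2cc(-c3ccccn3)nc(-c3ccccn3)c2)cc1`) has not yet been measured in this assay and differs from compound 2 at one place, with phenyl in place of thiophen-3-yl on an aromatic carbon. Among the measured compounds shown here, no measured pair shows this exchange, so the expectation is uncertain. Compound 3 keeps the two pyridin-2-yl groups of compound 2 at 0.29 ug/mL as the starting point, and no step beyond the scatter is expected. The expected change is a 1.4-fold higher number from compound 2 to compound 3 (0.14 log units; within the scatter) in size, a slight rise if any. For compound 3 the estimated value is 0.4 ug/mL with an expected range from 0.1 ug/mL to 2 ug/mL in this measurement.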

Compound 3, concentration for 50% growth inhibition: 0.37 ug/mL
Compound 3: the middle estimate sits 1.1-fold (0.03 log units) above what was measured; the range from low to high includes it.
By their numbers in this assay, from the lowest: compounds 2 and 3 (each within the scatter of the next); then compound 1.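

In this assay, the exchange of thiophen-3-yl for phenyl on the aromatic carbon opposite the ring nitrogen gives a 1.3-fold higher number from compound 2 to compound 3 (0.11 log units; within the scatter), so the two rings cannot be told apart at this position. Among the compounds shown here, the exchange of pyridin-3-yl for pyridin-2-yl, read here for the first time as a change in one place, gives a 110-fold lower number from compound 1 to compound 3 (2.04 log units; beyond the scatter), and so the placing of the nitrogen in that ring matters far more in this set than the ring exchanged in the other step. Nothing available explains either step.

The compounds shown leave open whether this holds for a pyridin-4-yl group in that place. They also leave open whether the carbon opposite the ring nitrogen accepts anything other than an aromatic ring, such as an amine or a longer chain.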